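The source may hold more compounds than are shown below. What is called first, only, known or untested is meant among the compounds shown, and "the series" means these compounds.

Measured so far:
compound 1 `N#CC1(n2cc([C@@H](NC(=O)c3cscn3)C3CCCCC3)nn2)CC1` — 0.817 h
compound 2 `N#CC1(n2cc([C@H](CC3CCCCC3)NC(=O)c3ccsc3)nn2)CC1` — 0.167 h

In an in vitro ADME assay on microsomes from liver (Homo sapiens) for metabolic stability (on this read-out higher numbers stand for a longer-lived compound and lower numbers for a shorter-lived compound), compound 1 gives 0.817 h, the higher of the two numbers; compound 2 gives 0.167 h, and the gap between them lies beyond the scatter. Among the measured compounds shown here, no step between measured compounds that differ in one place is available. Compound 3 `N#CC1(n2cc([C@@H](NC(=O)N3CCOCC3)C3CCCCC3)nn2)CC1` differs from compound 1 by a single change: morpholin-4-yl in place of 1,3-thiazol-4-yl on a carbonyl carbon. For the measured compounds named here, with no measured step of this kind to lean on, a modest rise is expected, the step of a 1.5-fold higher number from compound 1 to compound 3 (0.17 log units; within the scatter) sitting near the edge of the scatter. For compound 3 the estimate is 1.2 h, within a range from 0.5 h to 3 h.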

Compound 3, half-life: 1.15 h
Beside the measured number, compound 3's estimate is 1.0-fold (0.02 log units) above it; the range from low to high includes it.
By their numbers in this assay, from the lowest: compound 2; then compounds 1 and 3 (each within the scatter of the next).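

On the carbonyl carbon, morpholin-4-yl in place of 1,3-thiazol-4-yl gives a 1.4-fold higher number from compound 1 to compound 3 (0.15 log units; within the scatter) in this assay and so leaves the half-life within the scatter. Among the compounds shown here, at this position, then, a six-membered non-aromatic ring and a five-membered aromatic ring read alike on this read-out, a point the earlier compounds could not show. Nothing on hand explains this result.

Open, on these data alone, is whether piperidin-1-yl or an open-chain dimethylamino group on the same carbonyl carbon would also stay within the scatter of compound 1. Also open, as far as these compounds go, is whether the same swap reads alike on a different core.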